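Halogen Swap on a Flat Adenosine Series

The source may hold more compounds than are shown below. What is called first, only, known or untested is meant among the compounds shown, and "the series" means these compounds.

Measured compounds:
compound 1, `Cc1c(-c2ccccc2)sc(N)c1C(=O)c1ccc(Cl)cc1` — 1%
compound 2, `Nc1sc(-c2ccccc2)c(-c2ccccc2)c1C(=O)c1ccc(Cl)cc1` — 1%
compound 3, `CC(C)(C)Cc1c(-c2ccc(F)cc2)sc(N)c1C(=O)c1ccc(Cl)cc1` — 1%

All three were tested in an assay on CHO cells for displacement of a labelled ligand from adenosine receptor A1 (Homo sapiens), read by scintillation counting, tested at 10 uM (on this read-out lower numbers stand for less inhibition and higher numbers for more inhibition at the one concentration tested (going by the name of the read-out)), and all three sit at the floor of the read-out. Within the data shown here, the one step between compounds that differ in a single place, no change at the digits printed from compound 1 to compound 2 (within the scatter), brought no change. Compound 3 stands level with compound 1 and compound 2 at the digits shown; its nearest neighbour is compound 1 and its furthest compound 2, and neither gap reaches beyond the scatter.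

Compound 4, `CC(C)(C)Cc1c(-c2ccc(Cl)cc2)sc(N)c1C(=O)c1ccc(Cl)cc1`, has not yet been measured. It differs from compound 3 by chloro in place of fluoro on an aromatic carbon. Among the measured compounds shown here, no measured step bears directly on a halogen exchange of this kind; the only step available is a much larger one, and it left this assay unchanged. With every measured compound at the floor and no sign of movement anywhere in the set, a change of one halogen for another is expected to leave compound 4 where compound 3 stands, so the expected step of a number 1 percentage points higher from compound 3 to compound 4 (within the scatter) is none beyond the scatter. Compound 4 is therefore estimated at 2% in this assay, within a range from -6% to 12%.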

Compound 4, a percentage reported as inhibition, at one concentration (the size of the read-out at that concentration, not a potency): 1%
Compound 4: middle estimate off by 1 percentage points, on the high side, and the stated range covers the measured number.
By their numbers in this assay, from the lowest: compounds 1, 2, 3 and 4 (each within the scatter of the next).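

Among these compounds, the exchange of 4-fluorophenyl for 4-chlorophenyl gives the first direct reading of a halogen swap at this place, on an aromatic carbon para to a large group, and in this assay it shows no change at the digits printed from compound 3 to compound 4 (within the scatter) in a series where the only earlier single-place step was phenyl in place of methyl, at another place on the shared core. Among the compounds shown here, with both compounds at the floor of the read-out, the result shows only that this exchange does not lift the series off that floor, and it cannot show whether the two halogens would differ in a compound with measurable inhibition. No measurement at hand offers an explanation for this lack of movement.

The compounds shown leave open whether a group of a different kind at this place, such as an amine or a carboxylic acid, would bring any inhibition clear of the floor. They also leave open how the same exchange of fluoro and chloro would read on a compound standing well above the floor, where a step could show in either direction.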